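The source may report more compounds than this note shows. Statements on the series, on what has been measured and on what is new or still open speak of the compounds shown alone.

Three compounds built on a shared core were tested in a functional assay on HCT-116 cells (Homo sapiens) for cytotoxicity, read by MTT assay, with a stated time of 72 h; a higher number here means a weaker inhibitor, a lower number a stronger inhibitor. Compound 1 `Cc1cc(-c2ccccc2)n(/C(N)=N/S(=O)(=O)c2cc(C)c(Cl)cc2SCc2cccc(C(F)(F)F)c2)n1` gives 19000 nM. Compound 2 `Cc1cc(S(=O)(=O)/N=C(\N)n2nccc2-c2ccccc2)c(SCc2ccccc2)cc1Cl` gives 12000 nM, and compound 3 `Cc1cc(S(=O)(=O)/N=C(\N)n2nccc2-c2ccccc2)c(SCc2ccc(C(F)(F)F)cc2)cc1Cl` gives 14000 nM. Among these three numbers compound 1 sits at the high end, yet its distance to compound 3 and to compound 2 lies within the scatter of this assay, so on these figures the three compounds cannot be told apart. Within the data shown here, the single measured step that changes one place, a 1.2-fold higher number from compound 2 to compound 3 (0.07 log units; within the scatter), is likewise within the scatter.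

Compound 4 `Cc1cc(-c2ccccc2)n(/C(N)=N/S(=O)(=O)c2cc(C)c(Cl)cc2SCc2cccc(Cl)c2)n1` differs from compound 1 in one place: chloro in place of trifluoromethyl on an aromatic carbon. Among the measured compounds shown here, no measured pair exchanges chloro for trifluoromethyl, so the only guidance is the step from compound 2 to compound 3, a swap of groups on an aromatic carbon of the benzyl ring that moved this assay by an amount within the scatter. The change in compound 4 is of similar kind, and the expected step of a 1.1-fold lower number from compound 1 to compound 4 (0.05 log units; within the scatter) is therefore none beyond the scatter. Compound 4 is thus estimated at 17000 nM, with a range expected from 7000 nM to 40000 nM.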

Compound 4, half-maximal inhibitory concentration: 18000 nM
Beside the measured number, compound 4's estimate is 1.1-fold (0.02 log units) below it; low and high end bracket the measured number.
By their numbers in this assay, from the lowest: compounds 2, 3, 4 and 1 (each within the scatter of the next).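

Replacing trifluoromethyl with chloro on this aromatic carbon turns 3-(trifluoromethyl)benzyl into 3-chlorobenzyl and gives a 1.1-fold lower number from compound 1 to compound 4 (0.02 log units; within the scatter) in this assay, so a group of 4 heavy atoms gives way to a group of 1 heavy atom with no readable change in the result. Among these compounds, the only earlier step, a 1.2-fold higher number from compound 2 to compound 3 (0.07 log units; within the scatter), exchanged hydrogen for trifluoromethyl at a different place on the benzyl ring, so this is the first reading of a change at the position meta to a large group. No measurement is available that would explain this result.

The compounds shown leave open whether an amine, a hydroxyl group or a carboxylic acid at this place on the ring would shift the number beyond the scatter, as trifluoromethyl and chloro are the only two groups shown there. Among the compounds shown here, they also leave open what a longer chain in place of the benzyl group on the sulfur would do in this assay, where every compound so far reads alike.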